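Methyl in Place of Fluoro in a Flat Series

This account rests on a few compounds, and the source may have more. Where it says the series, first, only, none or still open, it means among the compounds named here.

Compound 1 `COC(=O)C(=N)/C=C(\O)c1ccccc1` gives 3% in an assay for inhibition of kynurenine 3-monooxygenase (Rattus norvegicus), tested at 10 uM; a higher number here means more inhibition at the concentration tested (going by the name of the read-out), a lower number less inhibition. Compound 2 `COC(=O)C(=N)/C=C(\O)c1ccc(Br)cc1` gives 0%. Compound 3 `COC(=O)C(=N)/C=C(\O)c1ccc(F)cc1` gives 1%.

Compound 3 sits second highest of the three numbers, but every gap is small: a number 1 percentage points higher from compound 2 to compound 3 (within the scatter) and a number 2 percentage points lower from compound 1 to compound 3 (within the scatter) both lie within the scatter, so the three compounds are indistinguishable here. Compound 4 `COC(=O)C(=N)/C=C(\O)c1ccc(C)cc1` carries the change (methyl in place of fluoro on an aromatic carbon). Among the measured compounds shown here, the steps that bear on it are the earlier exchanges at the same ring carbon, a number 3 percentage points lower from compound 1 to compound 2 (within the scatter) and a number 2 percentage points lower from compound 1 to compound 3 (within the scatter), both within the scatter. Another small group at this spot is therefore expected to leave the number where it is, an estimated a number 1 percentage points higher from compound 3 to compound 4 (within the scatter). Compound 4 is expected to give 2%, with a range from -8% to 12%.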

Compound 4, a percentage reported as inhibition, at one concentration (the size of the read-out at that concentration, not a potency): 4%
The estimate for compound 4 lay 2 percentage points below the measured number; the measured number falls inside the stated range.
By their numbers in this assay, from the lowest: compounds 2, 3, 1 and 4 (each within the scatter of the next).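

In this assay, methyl joins hydrogen, bromo and fluoro at this ring carbon without a readable change: a number 3 percentage points higher from compound 3 to compound 4 (within the scatter), a number 4 percentage points higher from compound 2 to compound 4 (within the scatter) and a number 1 percentage points higher from compound 1 to compound 4 (within the scatter). Methyl is the first carbon group at this position, and the four compounds still cannot be told apart. No measurement shown offers an explanation for this flat result.

On these data alone, whether any group at this ring carbon can produce clear inhibition remains open. An amine, a carboxylic acid or a longer chain here might read differently, as might a change elsewhere on the shared core.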